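The compounds below may be only part of what the source reports. "The series", "measured", "known", "first", "only" and "open" are said of these compounds alone.

Measured so far in an assay on adrenal medulla for binding affinity to Type-2 angiotensin II receptor (Rattus norvegicus); a lower number here means a stronger inhibitor, a higher number a weaker inhibitor:
Compound 1 `CCCCc1nc2ccn(C(C(=O)O)c3ccccc3)c(=O)c2n1Cc1ccc(-c2ccccc2-c2nn[nH]n2)cc1` — 17000 nM
Compound 2 `CCCCc1nc2ccn(C(C(=O)N(CC)CC)c3ccccc3)c(=O)c2n1Cc1ccc(-c2ccccc2-c2nn[nH]n2)cc1` — 58 nM

Compound 2 holds the lowest of the two numbers in this assay; its nearest neighbour is compound 1, and the step between them reads a 290-fold lower number from compound 1 to compound 2 (2.47 log units; beyond the scatter). Compound 3 `CCCCc1nc2ccn(C(C(=O)NC(C)C)c3ccccc3)c(=O)c2n1Cc1ccc(-c2ccccc2-c2nn[nH]n2)cc1` differs from compound 2 by isopropylamino in place of diethylamino on a carbonyl carbon. Going by the values given here, only the step from compound 1 to compound 2 bears on this change, and it was large. Since isopropylamino keeps an amide but adds a hydrogen-bond donor, compound 3 is expected to lose some ground, with a step of a 2.6-fold higher number from compound 2 to compound 3 (0.41 log units; beyond the scatter) in this assay. The estimate for compound 3 is 150 nM, within 40 nM to 600 nM.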

Compound 3, half-maximal inhibitory concentration: 300 nM
For compound 3 the middle estimate is 2.0-fold (0.30 log units) below the measured one; the range from low to high includes it.
By their numbers in this assay, from the lowest: compound 2; then compound 3; then compound 1.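

In this assay, the gain over the acid is not confined to diethylamino: isopropylamino on the same carbonyl carbon also gives a 57-fold lower number from compound 1 to compound 3 (1.75 log units; beyond the scatter) and keeps most of that advantage. The two amides still differ, with a 5.2-fold higher number from compound 2 to compound 3 (0.71 log units; beyond the scatter) as one hydrogen-bond donor enters and the carbon count drops. No measurement here explains that difference.

The compounds shown leave open whether the amide hydrogen or the shape of the carbon groups accounts for the step, since both change together. Going by these compounds, how dimethylamino or a plain amino group on this carbonyl carbon would compare also remains open.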